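The source may hold more compounds than are shown below. What is called first, only, known or untested is meant among the compounds shown, and "the series" means these compounds.

Measured compounds in a functional assay on A549 cells (Homo sapiens), read by MTT assay, with a stated time of 72 h; on this read-out lower numbers stand for stronger inhibition and higher numbers for weaker inhibition:
compound 1 `COc1ncnc2c1c(-c1cccs1)cn2[C@@H]1O[C@H](CO)[C@@H](O)[C@H]1O` gives 4850 nM
compound 2 `COc1ncnc2c1c(-c1ccccc1)cn2[C@@H]1O[C@H](CO)[C@@H](O)[C@H]1O` gives > 20000 nM, which is a limit of the assay rather than a number
compound 3 `CNc1ncnc2c1c(-c1ccco1)cn2[C@@H]1O[C@H](CO)[C@@H](O)[C@H]1O` gives 2570 nM

Compound 3 holds the lowest of the two numbers available in this assay; its nearest neighbour is compound 1, whose number lies within the scatter of it, so no order between the two can be read. The third entry, for compound 2, is only a limit. Compound 4 `COc1ncnc2c1c(-c1ccco1)cn2[C@@H]1O[C@H](CO)[C@@H](O)[C@H]1O` follows from compound 3 by methoxy in place of methylamino on an aromatic carbon.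

Among the measured compounds shown here, the single measured step, an at least 4.1-fold higher number from compound 1 to compound 2 (0.61 log units; beyond the scatter), concerns the group on the five-membered ring and not the group exchanged here, so no measured step bears directly on the change from compound 3 to compound 4. Compounds 1 and 3 differ in two places at once, one of them the same exchange of methoxy for methylamino, and their numbers lie within the scatter of each other; this gives no sign that the exchange moves the number far either way. The step is therefore expected to be small, a 1.6-fold higher number from compound 3 to compound 4 (0.19 log units; within the scatter), with no direction beyond the scatter. Compound 4 is estimated at 4000 nM, in the range 1500 nM to 12000 nM.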

Compound 4, half-maximal inhibitory concentration: 30 nM
Compound 4: the middle estimate sits 130-fold (2.12 log units) above what was measured; the whole stated range lies above it.
By their numbers in this assay, from the lowest: compound 4; then compounds 3 and 1 (each within the scatter of the next). At a limit, above all of these: compound 2.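

In this assay, among the compounds shown here, the step of an 86-fold lower number from compound 3 to compound 4 (1.93 log units; beyond the scatter) is the first measured one at this place, on an aromatic carbon opposite the ring nitrogen, and it shows that the group here can decide the read-out, with methoxy and methylamino far apart despite carrying the same count of heavy atoms. For the compounds shown here, the group on the five-membered ring proves just as decisive once methoxy is held fixed, since the step of a 160-fold lower number from compound 1 to compound 4 (2.21 log units; beyond the scatter) is large for furan-2-yl in place of thiophen-2-yl and extends the single earlier step on that group. The step of an at least 660-fold lower number from compound 2 to compound 4 (2.82 log units; beyond the scatter) is also large, but it gives only a bound, as the value of compound 2 is a limit and not a number: the limit of > 20000 nM in this assay, at which 1 of the 4 values shown sits.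

Going by these compounds, whether methoxy in place of methylamino carries the same size with thiophen-2-yl or phenyl stays open, as only the furan-2-yl pair reads this exchange directly. How an ethoxy group, a dimethylamino group or a chlorine atom would read at this place is also open, and the compounds shown give no cause for the size of either step.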